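Amide-nitrogen group change from compound 1 to compound 4

The source may report more compounds than this note shows. Statements on the series, on what has been measured and on what is new or still open speak of the compounds shown alone.

Values so far in a physicochemical assay for lipophilicity, at pH 7.4 (a lower number here means a more polar compound, a higher number a more lipophilic compound), are these:
compound 1 `CNC(=O)c1cc(C(=O)N[C@H]2[C@@H]3C[C@@H](O)C[C@@H]32)cc2c1OC[C@H]2c1ccccc1` gives 2.9
compound 2 `CC[C@@]1(c2ccccc2)COc2c(C(=O)NC)cc(C(=O)N[C@H]3[C@@H]4COC[C@@H]43)cc21` gives 4.2
compound 3 `CNC(=O)c1cc(C(=O)N[C@H]2[C@@H]3COC[C@@H]32)cc2c1OC[C@@]2(C)c1ccccc1` gives 3.7

Compound 1 holds the lowest of the three numbers, and its nearest neighbour is compound 3, with compound 2 furthest away. The change to compound 4 `CNC(=O)c1cc(C(=O)NCCC[C@H]2OC[C@H](N)CO2)cc2c1OC[C@H]2c1ccccc1` is a group of 10 heavy atoms (7 carbon, 1 nitrogen, 2 oxygen; one six-membered non-aromatic ring with 2 hetero atoms) in place of a group of 7 heavy atoms (6 carbon, 1 oxygen; one three-membered non-aromatic ring of carbon only, one five-membered non-aromatic ring of carbon only), on an amide-type nitrogen and the core of compound 1 stays as it is.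

Within the data shown here, only one measured step isolates a single change, a number 0.50 log units lower from compound 2 to compound 3 (beyond the scatter) and that change lies on the core, not on the amide-type nitrogen. It therefore serves only as a yardstick of size. Among the measured compounds shown here, compound 1 differs from compound 2 and from compound 3 in more than one place, so those gaps give no clean step, and no measured case of the present change exists.

Taking a number 0.50 log units lower from compound 2 to compound 3 (beyond the scatter) as the yardstick, a larger step is expected for this bigger change, towards a lower number in this assay on the counted hetero atoms and acceptors of the entering group. The estimated move is a number 0.80 log units lower from compound 1 to compound 4 (beyond the scatter) with wide uncertainty. For compound 4 the estimate is 2.1 with an expected range from 1.4 to 2.8 in this measurement.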

Compound 4, distribution coefficient: 2.6
Beside the measured number, compound 4's estimate is 0.50 log units below it; the range from low to high includes it.
By their numbers in this assay, from the lowest: compounds 4 and 1 (each within the scatter of the next); then compound 3; then compound 2.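

Among these compounds, compound 1 and compound 4 share the core, so this is the first clean reading at the amide-type nitrogen, and in this assay the exchange gives a number 0.30 log units lower from compound 1 to compound 4 (within the scatter). At this position on the core of compound 1, the ring type, heavy-atom count and counted hydrogen-bond acceptors all differ between the leaving and entering groups (3 hydrogen-bond acceptors in the entering group, 1 in the leaving group), yet the two values cannot be separated, unlike the step on the core from compound 2 to compound 3, which is printed as beyond the scatter. No measurement in hand bears on why the two values stand together.

The entering group brings a chain, a six-membered non-aromatic ring with 2 hetero atoms and an amine as one unit, so the compounds shown do not tell whether each part alone would leave the value equally unmoved. A simple alkyl chain without the ring, or a carboxylic acid in place of the amine, on the same core would separate these parts, and the same exchange on the core of compound 2 or compound 3 remains an open case.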